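The compounds below may be only part of what the source reports. "The series", "measured", "known", "first", "only" and "open" are said of these compounds alone.

Measured so far:
Compound 1 `CC[C@@H]1/C=C(\C)C[C@H](C)C[C@H](OC)[C@H]2O[C@@](O)(C(=O)C(=O)N3CCCC[C@H]3C(=O)O[C@H](/C(C)=C/[C@@H]3CC[C@@H](Oc4ccccc4)[C@H](OC)C3)[C@H](C)[C@@H](O)CC1=O)[C@H](C)C[C@@H]2OC`: in a functional assay on cells for inhibition, with Murine T-cell line (Mus musculus) as the target (on this read-out lower numbers stand for stronger inhibition and higher numbers for weaker inhibition), compound 1 gives 5.4 nM.
Compound 2 `CC[C@@H]1/C=C(\C)C[C@H](C)C[C@H](OC)[C@H]2O[C@@](O)(C(=O)C(=O)N3CCCC[C@H]3C(=O)O[C@H](/C(C)=C/[C@@H]3CC[C@@H](Oc4ccc(F)cc4)[C@H](OC)C3)[C@H](C)[C@@H](O)CC1=O)[C@H](C)C[C@@H]2OC`: in this assay compound 2 gives 3.4 nM.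

Compound 2 and compound 1 lie within the scatter of each other, as a 1.6-fold lower number from compound 1 to compound 2 (0.20 log units; within the scatter) shows, so the two cannot be separated on these numbers. Compound 3 `CC[C@@H]1/C=C(\C)C[C@H](C)C[C@H](OC)[C@H]2O[C@@](O)(C(=O)C(=O)N3CCCC[C@H]3C(=O)O[C@H](/C(C)=C/[C@@H]3CC[C@@H](Oc4cccc(O)c4)[C@H](OC)C3)[C@H](C)[C@@H](O)CC1=O)[C@H](C)C[C@@H]2OC` differs from compound 2 by 3-hydroxyphenyl in place of 4-fluorophenyl on an oxygen on a saturated carbon. Among the compounds with values here, only one measured step touches this part of the structure, the fluoro for hydrogen exchange, and it stayed within the scatter; no measured step brings in a hydroxy group, so the data give no direction for it. For compound 3 the estimated step is a 1.8-fold higher number from compound 2 to compound 3 (0.25 log units; within the scatter). Compound 3 is expected at 6 nM, with a range of 2 nM to 20 nM.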

Compound 3, half-maximal inhibitory concentration: 1.7 nM
Compound 3: middle estimate off by 3.5-fold (0.55 log units), on the high side; measured number outside the range, below it.
By their numbers in this assay, from the lowest: compounds 3, 2 and 1 (each within the scatter of the next, the first and the last beyond it).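

Hydroxy in place of hydrogen on the aromatic ring gives a 3.2-fold lower number from compound 1 to compound 3 (0.50 log units; beyond the scatter), the first step at this position to clear the scatter in this assay. Exchanging 4-fluorophenyl for 3-hydroxyphenyl gives a 2.0-fold lower number from compound 2 to compound 3 (0.30 log units; within the scatter), so the fluoro and hydroxy compounds remain unseparated. No measured evidence bears on the origin of the hydroxy step.

Open, on these data alone, is whether 4-hydroxyphenyl would match 3-hydroxyphenyl on this oxygen. Also open, as far as these compounds go, is whether a methoxy group, an amine or a carboxylic acid on the ring would keep the number as low.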